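The source may report more compounds than this note shows. Statements on the series, on what has been measured and on what is new or still open speak of the compounds shown alone.

Measured so far: compound 1 `CCC(=O)N1N=C(c2ccc(F)cc2)CC1c1ccc(C)cc1` gives 10000 nM in an assay on isolated protein for inhibition of Amine oxidase [flavin-containing] A (Bos taurus); a higher number here means a weaker inhibitor, a lower number a stronger inhibitor; compound 2 `CCC(=O)N1N=C(c2ccc(OC)cc2)CC1c1ccc(Cl)cc1` gives 832 nM; compound 3 `CCC(=O)N1N=C(c2ccc(OC)cc2)CC1c1ccc(F)cc1` gives 1000 nM.

Compound 3 stands second highest of the three numbers in this assay, nearest compound 2 and furthest from compound 1. Compound 4 `CCC(=O)N1N=C(c2ccc(OC)cc2)CC1c1ccc(C)cc1` differs from compound 3 by methyl in place of fluoro on an aromatic carbon. Going by the values given here, the only measured step on that ring, a 1.2-fold higher number from compound 2 to compound 3 (0.08 log units; within the scatter), was a halogen swap and stayed within the scatter. Compound 1 also carries the methyl on this ring, but differs from compound 3 in a second place as well, so its higher number cannot be assigned to the methyl alone. A modest weakening is therefore expected, a 2.0-fold higher number from compound 3 to compound 4 (0.30 log units; within the scatter). Compound 4 is estimated at 2000 nM, within 700 nM to 6000 nM.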

Compound 4, half-maximal inhibitory concentration: 7240 nM
Estimate against measurement, compound 4: 3.6-fold (0.56 log units) below; the whole stated range lies below it.
By their numbers in this assay, from the lowest: compounds 2 and 3 (each within the scatter of the next); then compounds 4 and 1 (each within the scatter of the next).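

In this assay this position distinguishes methyl from the halogens: a 7.2-fold higher number from compound 3 to compound 4 (0.86 log units; beyond the scatter) and an 8.7-fold higher number from compound 2 to compound 4 (0.94 log units; beyond the scatter) are both beyond the scatter, whereas the fluoro and chloro compounds stayed within it. With 4-methylphenyl in place, swapping methoxy for fluoro on the other ring gives a 1.4-fold lower number from compound 1 to compound 4 (0.14 log units; within the scatter) and so shows no clear effect, on this single pair. No available evidence gives a cause for the loss with methyl.

Going by these compounds, whether an ethyl, an amine or a hydroxyl at this position behaves like methyl remains open. Also open, on these data alone, is whether methoxy and fluoro on the other ring still match when this ring carries a halogen.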